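This account rests on a few compounds, and the source may have more. Where it says the series, first, only, none or still open, it means among the compounds named here.

In a functional assay on MCF7 cells (Homo sapiens) for antiproliferative activity, read by MTT assay (on this read-out higher numbers stand for weaker inhibition and lower numbers for stronger inhibition), compound 1 (`COc1cc2c(Oc3ccc(NC(=O)Nc4ccc(OC(F)(F)F)cc4)cc3)ccnc2cc1OCCCCCCC(=O)NO`) gives 3200 nM, compound 2 (`COc1cc2c(Oc3ccc(NC(=O)Nc4ccc(C)cc4C)cc3)ccnc2cc1OCCCCCCC(=O)NO`) gives 3430 nM, and compound 3 (`COc1ccccc1NC(=O)Nc1ccc(Oc2ccnc3cc(OCCCCCCC(=O)NO)c(OC)cc23)cc1`) gives 6280 nM. Compound 3 stands within the scatter of both others, with a 2.0-fold higher number from compound 1 to compound 3 (0.29 log units; within the scatter) and a 1.8-fold higher number from compound 2 to compound 3 (0.26 log units; within the scatter). Compound 4 (`COc1cc2c(Oc3ccc(NC(=O)NNC(=O)c4ccccc4)cc3)ccnc2cc1OCCCCCCC(=O)NO`) has benzamido in place of 2-methoxyphenyl on an amide-type nitrogen. The nearest evidence is these two steps and a 1.1-fold higher number from compound 1 to compound 2 (0.03 log units; within the scatter), all within the scatter. Each exchanges one substituted phenyl group for another, and none introduces benzamido, so they offer only indirect guidance. As far as these compounds go, no change beyond the scatter is therefore expected in this assay, and the direction remains open. The expected step is a 1.3-fold lower number from compound 3 to compound 4 (0.10 log units; within the scatter). For compound 4 the estimated value is 5000 nM, with an expected range from 1800 nM to 14000 nM.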

Compound 4, half-maximal inhibitory concentration: 2450 nM
Beside the measured number, compound 4's estimate is 2.0-fold (0.31 log units) above it; measured number inside the range.
By their numbers in this assay, from the lowest: compounds 4, 1, 2 and 3 (each within the scatter of the next, the first and the last beyond it).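

In this assay, among the compounds shown here, benzamido on this amide-type nitrogen gives the first step beyond the scatter at this position (a 2.6-fold lower number from compound 3 to compound 4 (0.41 log units; beyond the scatter)), while the earlier exchanges among substituted phenyl groups all stayed within it. Against the other two groups the same exchange stays within the scatter (a 1.4-fold lower number from compound 2 to compound 4 (0.15 log units; within the scatter); a 1.3-fold lower number from compound 1 to compound 4 (0.12 log units; within the scatter)), so the separation holds only against 2-methoxyphenyl. Nothing given here accounts for this step. The compounds shown leave open whether the carbonyl or the phenyl ring of benzamido matters, which an acetamido group on this nitrogen would help separate.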